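This account rests on a few compounds, and the source may have more. Where it says the series, first, only, none or still open, it means among the compounds named here.

Of the compounds shown here, three have so far been tested in a functional assay on A2780 cells (Homo sapiens) for cytotoxicity, read by sulforhodamine B assay, with a stated time of 72 h; on this read-out lower numbers stand for stronger inhibition and higher numbers for weaker inhibition. Compound 1 `O=C(NCc1ccc(S(=O)(=O)c2ccccc2)cc1)c1cc2cnccc2[nH]1` gives 18 nM. Compound 2 `O=C(NCc1ccc(S(=O)(=O)c2ccccc2)cc1)N1CCc2ccncc2C1` gives > 2000 nM, which is a limit of the assay and not a number. Among the compounds with values here, compound 3 `CC(C)n1cc(S(=O)(=O)c2ccc(CNC(=O)N3Cc4ccncc4C3)cc2)cn1` gives 11 nM, and this value lies within the usual scatter of the one for compound 1, so the two numbers stand together and neither can be ranked over the other.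

Compound 4 `CCC(=O)N1CCC(S(=O)(=O)c2ccc(CNC(=O)N3Cc4ccncc4C3)cc2)CC1` has not yet been measured in this assay. Its difference from compound 3 is 1-propanoylpiperidin-4-yl in place of 1-isopropyl-1H-pyrazol-4-yl on a sulfonyl sulfur. Within the data shown here, no pair of tested compounds differs in one place only, so no measured step is available as a guide. The expectation rests instead on compound 3 at 11 nM and compound 1 at 18 nM, two close numbers from different structures, although compound 2 shows that this closeness does not hold for every structure tested. A small change is therefore expected, and a 1.4-fold higher number from compound 3 to compound 4 (0.13 log units; within the scatter) is estimated as a slight rise in the number, within the usual scatter. For compound 4 the expected value is 15 nM, with an estimated range of 4 nM to 60 nM.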

Compound 4, half-maximal inhibitory concentration: 54 nM
Compound 4: middle estimate off by 3.6-fold (0.56 log units), on the low side; measured number inside the range.
By their numbers in this assay, from the lowest: compounds 3 and 1 (each within the scatter of the next); then compound 4. At a limit, above all of these: compound 2.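

In this assay, within the data shown here, putting 1-propanoylpiperidin-4-yl in place of 1-isopropyl-1H-pyrazol-4-yl on a sulfonyl sulfur gives a 4.9-fold higher number from compound 3 to compound 4 (0.69 log units; beyond the scatter), the first single-place change that can be read, and it shows that the group at this position affects the read-out. The step is modest, and compound 4 still gives 54 nM, so a six-membered non-aromatic ring carrying a propanoyl group can stand here in place of a five-membered aromatic ring with only a limited rise in the number. Nothing measured here gives a cause for this step.

The step changes the ring and brings in the propanoyl group at once, so the compounds shown do not tell which of the two accounts for the rise in the number. From the compounds shown here alone, it remains open how a piperidine with a free amine, an acetyl group or a longer acyl chain on its nitrogen, or a pyrazole carrying a methyl group in place of the isopropyl group, would read in this assay.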